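The source may report more compounds than this note shows. Statements on the series, on what has been measured and on what is new or still open speak of the compounds shown alone.

Within the data shown here, in a functional assay on MV4-11 cells (Homo sapiens) for antiproliferative activity, read by CellTiter-Glo, with a stated time of 72 h (on this read-out higher numbers stand for weaker inhibition of growth and lower numbers for stronger inhibition of growth), compound 2 `COCCN[C@H]1CC[C@H](Nc2cc(-c3csc(NCc4ccc(F)cc4)n3)c(Cl)cn2)CC1` gives 880 nM, the only exact number so far. Compound 1 `COCCN[C@H]1CC[C@H](Nc2cc(-c3csc(NCC4CCC4)n3)c(Cl)cn2)CC1` reads > 10000 nM, which is a limit of the assay. Among the measured compounds shown here, the one measured step at this place is an at least 11-fold lower number from compound 1 to compound 2 (1.05 log units; beyond the scatter). Compound 3 `COCCN[C@H]1CC[C@H](Nc2cc(-c3csc(NCC4CCOC4)n3)c(Cl)cn2)CC1` differs from compound 2 by oxolan-3-yl in place of 4-fluorophenyl on a saturated chain carbon bound to a nitrogen on an aromatic ring, with oxolan-3-yl in place of 4-fluorophenyl. The entering ring is non-aromatic, as is the cyclobutyl of compound 1, so a large part of an at least 11-fold lower number from compound 1 to compound 2 (1.05 log units; beyond the scatter) is expected to reverse, towards weaker inhibition of growth. The expected change is a 5.7-fold higher number from compound 2 to compound 3 (0.75 log units; beyond the scatter). Compound 3 is estimated at 5000 nM, with an expected range of 1500 nM to 10000 nM.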

Compound 3, concentration for 50% growth inhibition: 493 nM
Beside the measured number, compound 3's estimate is 10-fold (1.01 log units) above it; the whole stated range lies above it.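

At this place, on a saturated chain carbon bound to a nitrogen on an aromatic ring, an aromatic ring is not required for activity in this assay: there is a 1.8-fold lower number from compound 2 to compound 3 (0.25 log units; within the scatter). The non-aromatic rings do not read alike, with an at least 20-fold lower number from compound 1 to compound 3 (1.30 log units; beyond the scatter). That step gives only a minimum size, since compound 1 stands at a limit: the limit of > 10000 nM in this assay, at which 1 of the 3 values shown sits.

Whether the ring oxygen of oxolan-3-yl accounts for the step from cyclobutyl stays open. A tetrahydropyran-4-yl or a piperidin-4-yl ring at the same place would bear on this.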